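Oxime to dichlorobenzyl ether: expected change in cell toxicity

The source may hold more compounds than are shown below. What is called first, only, known or untested is meant among the compounds shown, and "the series" means these compounds.

Compound 1 `COC(=O)C1C(=O)C(C(=O)OC)[C@H](c2cccc([N+](=O)[O-])c2)N(Cc2ccc(C)cc2)[C@@H]1c1cccc([N+](=O)[O-])c1` gives 49.8 uM in an ADME assay on J774.1 cells (Mus musculus) for cytotoxicity, with a stated time of 48 h; a lower number here means that less compound is needed, a higher number that more compound is needed for the effect. Compound 2 `COC(=O)C1C(=O)C(C(=O)OC)[C@H](c2ccccn2)N(CCCC(=O)O)[C@@H]1c1ccccn1` gives 46 uM in this assay. Compound 3 `O/N=C/C1CCN(CCCc2ccccc2)CC1` gives > 100 uM in this assay.

The value of compound 3 is a limit of the measurement, not a number, so all that is known is that compound 3 sits at the limit of > 100 uM in this assay, at which 1 of the 3 values shown sits. Compound 1 and compound 2 give numbers that sit within the scatter of each other.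

Compound 4 `Clc1cccc(Cl)c1CO/N=C/C1CCN(CCCc2ccccc2)CC1` differs from compound 3 in one place: 2,6-dichlorobenzyl in place of hydrogen on an oxygen. Among the compounds with values here, no measured pair shows what such an addition does in this assay, so the direction must be guessed. The expectation is that the step from compound 3 to compound 4 moves toward a lower number, beyond the scatter, by about an at least 2.5-fold lower number from compound 3 to compound 4 (0.39 log units; beyond the scatter). Compound 4 is therefore expected to give about 40 uM in this assay, most likely between 12 uM and 100 uM.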

Compound 4, concentration for half-maximal effect: 28.4 uM
Compound 4: middle estimate off by 1.4-fold (0.15 log units), on the high side; measured number inside the range.
By their numbers in this assay, from the lowest: compounds 4, 2 and 1 (each within the scatter of the next). At a limit, above all of these: compound 3.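

Placing 2,6-dichlorobenzyl in place of hydrogen on this oxygen gives the only measured step at this position in this assay: an at least 3.5-fold lower number from compound 3 to compound 4 (0.54 log units; beyond the scatter). The step lies beyond the scatter and points toward less compound being needed for the cytotoxic effect, so a change at this oxygen can alter the number in these cells. Compound 3 stands at a limit and not at a number, so the step gives only a bound and its true size stays open: the limit of > 100 uM in this assay, at which 1 of the 4 values shown sits.

Whether the chlorine atoms matter or the benzyl group alone is enough cannot be told, as a plain benzyl or a small methyl on this oxygen lies outside the compounds shown. Also open, going by these compounds, is what an amine or a carboxylic acid at the end of a longer chain would do at the same place.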